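Benzamide versus urea on the anilide side of the series

The source may hold more compounds than are shown below. What is called first, only, known or untested is meant among the compounds shown, and "the series" means these compounds.

Measured so far in a functional assay on KM12 cells (Homo sapiens) for inhibition, read by sulforhodamine B assay, with a stated time of 48 h; a higher number here means a weaker inhibitor, a lower number a stronger inhibitor:
compound 1 `COc1cc(-c2nn(-c3cccc(NC(=O)c4cccc(C(F)(F)F)c4)c3)cc2-c2ccncc2)ccc1Cl`: 1660 nM
compound 2 `COc1cc(-c2nn(-c3cccc(NC(=O)Nc4ccc(Cl)c(Cl)c4)c3)cc2-c2ccncc2)ccc1Cl`: 810 nM
compound 3 `COc1cc(-c2nn(-c3cccc(NC(=O)Nc4ccc(Cl)c(C(F)(F)F)c4)c3)cc2-c2ccncc2)ccc1Cl`: 1060 nM

Compound 3 sits second highest of the three numbers. Its nearest neighbour is compound 2, and that gap, a 1.3-fold higher number from compound 2 to compound 3 (0.12 log units; within the scatter), lies within the scatter. Its furthest neighbour is compound 1, and that gap, a 1.6-fold lower number from compound 1 to compound 3 (0.19 log units; within the scatter), also lies within the scatter, so the three measured values cannot be separated by order.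

Compound 4 `COc1cc(-c2nn(-c3cccc(NC(=O)c4ccccc4)c3)cc2-c2ccncc2)ccc1Cl` is not yet measured. It differs from compound 3 by phenyl in place of (4-chloro-3-(trifluoromethyl)phenyl)amino on a carbonyl carbon. The urea of compound 3 is thus reduced to an unsubstituted benzamide on the shared core.

The step that bears most directly on this change is the reverse of a 1.6-fold lower number from compound 1 to compound 3 (0.19 log units; within the scatter), where a benzamide carrying a trifluoromethyl group went to the urea of compound 3 without leaving the scatter. Among the measured compounds shown here, compound 4 additionally lacks any substituent on the entering phenyl; no measured pair shows that change, so nothing beyond the amide-to-urea comparison can be drawn on. A small rise in the number is therefore expected, roughly the size of the urea-to-amide steps seen, not clearly beyond the scatter.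

For compound 4 the estimated value in this assay is 2000 nM, with a range of 900 nM to 4500 nM; the expected step is a 1.9-fold higher number from compound 3 to compound 4 (0.28 log units; within the scatter).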

Compound 4, half-maximal inhibitory concentration: 560 nM
Estimate against measurement, compound 4: 3.6-fold (0.55 log units) above, outside the stated range (below it).
By their numbers in this assay, from the lowest: compounds 4, 2, 3 and 1 (each within the scatter of the next, the first and the last beyond it).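

In this assay, hydrogen in place of trifluoromethyl on an aromatic carbon of the benzamide gives a 3.0-fold lower number from compound 1 to compound 4 (0.47 log units; beyond the scatter) and clears the scatter, so the trifluoromethyl group of compound 1 is not required for activity on this scaffold. With phenyl on the carbonyl carbon in place of (4-chloro-3-(trifluoromethyl)phenyl)amino, the result is a 1.9-fold lower number from compound 3 to compound 4 (0.28 log units; within the scatter) and remains inside the scatter, and with phenyl in place of (3,4-dichlorophenyl)amino the result is a 1.4-fold lower number from compound 2 to compound 4 (0.16 log units; within the scatter) and likewise remains inside it, so compound 4 cannot be separated from either urea. The earlier 2.0-fold lower number from compound 1 to compound 2 (0.31 log units; beyond the scatter) therefore cannot be read as a gain from the urea alone, since the unsubstituted benzamide gives up nothing measurable against compound 2.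

Still open, on these data alone, is how a plain phenylamino group on the carbonyl carbon would compare with compound 4, and whether a methoxy group or an amine on the phenyl ring would behave as trifluoromethyl does. No measurement shown here explains the difference between compound 1 and compound 4.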